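Series notes: compound 4 expected from compound 1

The compounds below may be only part of what the source reports. "The series", "measured", "known", "first", "only" and "open" are said of these compounds alone.

Measured so far:
compound 1 `CC/N=C(\N)Nc1ccc(Sc2ccc(OC)cc2)cc1`, 251 nM
compound 2 `CC/N=C(\N)Nc1ccc(Sc2ccc(Cl)cc2)cc1`, 631 nM
compound 3 `c1cc(Sc2ccc3c(c2)OCCO3)ccc1NC1=NCCN1`, 631 nM

In an assay (Rattus norvegicus) for binding affinity to prostacyclin receptor (Homo sapiens), read by radioligand binding (a lower number here means a stronger inhibitor, a higher number a weaker inhibitor), compound 1 gives the lowest of the three numbers, and its nearest neighbours, compound 2 and compound 3, both sit a step beyond the scatter above it. Compound 4 `COc1ccc(Sc2ccc(NC3=NC(C)(C)CN3)cc2)cc1` differs from compound 1 by a group of 7 heavy atoms (5 carbon, 2 nitrogen; one five-membered non-aromatic ring with 2 hetero atoms) in place of a group of 5 heavy atoms (3 carbon, 2 nitrogen; no ring), on a nitrogen on an aromatic ring. Among the compounds with values here, the only measured step, a 2.5-fold higher number from compound 1 to compound 2 (0.40 log units; beyond the scatter), concerns the other aromatic ring and does not bear on this change. Within the data shown here, compound 3 carries a ring of this kind on the same nitrogen together with a different second ring, and its value, alongside that of compound 1, shows a somewhat higher number; no single-change step links them. Compound 4 is therefore expected near compound 1 or modestly weaker, a 1.6-fold higher number from compound 1 to compound 4 (0.20 log units; within the scatter), with an estimate of 400 nM (range 130 nM to 1300 nM).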

Compound 4, inhibition constant: 631 nM
Estimate against measurement, compound 4: 1.6-fold (0.20 log units) below; the range from low to high includes it.
By their numbers in this assay, from the lowest: compound 1; then compounds 2, 3 and 4 (each within the scatter of the next).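

In this assay, within the data shown here, the change on a nitrogen on an aromatic ring can now be read directly for the first time: a 2.5-fold higher number from compound 1 to compound 4 (0.40 log units; beyond the scatter). On the core of compound 1, the group with one five-membered non-aromatic ring with 2 hetero atoms therefore keeps measurable binding, with a modest loss beyond the scatter. No available measurement explains this step. On these data alone, it remains open how the same ring without its two methyl groups, or a propyl chain in place of the ethyl chain, would read on this core. As far as these compounds go, whether the step carries over to the chloro compound 2 also remains open.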